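Swapping the Aryl Group on a Sulfur Linker

A few compounds are considered here, and "the series" means these few. Any claim that something is new, unique, unknown or untested is made for them only; others in the source may bear on it.

Measured compounds:
compound 1 `Cc1cc(C)cc(SCc2ccc(/C=C/C(=O)Nc3ccccc3N)cc2)c1`: 47.3%
compound 2 `Nc1ccccc1NC(=O)c1ccc(CSCCc2ccccc2)cc1`: 84.1%

In a functional assay on A549 cells (Homo sapiens) for inhibition, read by CCK-8 assay, with a stated time of 72 h, tested at 8 uM (a lower number here means less inhibition of growth, a higher number more inhibition of growth at the concentration tested), compound 1 gives 47.3%, the lower of the two numbers shown, while compound 2 gives 84.1%, a number higher by more than the usual scatter. Compound 3 `CC(C)(C)c1ccc(SCc2ccc(/C=C/C(=O)Nc3ccccc3N)cc2)cc1` has not yet been measured. It differs from compound 1 in one place: 4-(tert-butyl)phenyl in place of 3,5-dimethylphenyl on a sulfur. Among the measured compounds shown here, no step between measured compounds matches this change, so no shift beyond the scatter is expected in this assay. Compound 3 is estimated at 50% (30% to 70%), and the step of a number 2.7 percentage points higher from compound 1 to compound 3 (within the scatter) is expected to be small.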

Compound 3, percent growth inhibition at one concentration: 79.8%
Estimate against measurement, compound 3: 29.8 percentage points below; the whole stated range lies below it.
By their numbers in this assay, from the lowest: compound 1; then compounds 3 and 2 (each within the scatter of the next).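

The aryl group on the sulfur is not a neutral place to change: in this assay, 4-(tert-butyl)phenyl in place of 3,5-dimethylphenyl gives a number 32.5 percentage points higher from compound 1 to compound 3 (beyond the scatter). Both groups have one six-membered aromatic ring of carbon only and no net charge, so a change in the carbon groups on that ring alone is enough to move growth inhibition this far. No measurement shown here bears on the reason for this step.

This single pair cannot separate the effect of the tert-butyl group from that of its place on the ring. On these data alone, how an amine or a carboxylic acid on that ring would behave also remains open.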